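Swapping the side chain of compound 2 for isopropyl

The compounds below may be only part of what the source reports. "The series", "measured", "known", "first", "only" and "open" are said of these compounds alone.

Compound 2 `N=C(N)NCCC[C@H](NC(=O)CN(c1ncnc2c1ncn2C1CCCCO1)C1CC1)C(=O)OCc1ccccc1` was tested in a functional assay on the whole organism (Tail, strain ICR) with Mus musculus as the target, in the tail flick test, with a stated time of 60 min, at a dose of 25 umol/kg by the oral route (on this read-out higher numbers stand for a stronger effect at the one dose given and lower numbers for a weaker effect), and gives 52.4%. Within the data shown here, its only measured neighbour, compound 1 `O=C(CN(c1ncnc2c1ncn2C1CCCCO1)C1CC1)N[C@@H](CO)C(=O)OCc1ccccc1`, gives 46.7% in this assay, and the two numbers lie within the scatter of each other, so neither can be called the more active. Among the measured compounds shown here, the one measured step, a number 5.7 percentage points higher from compound 1 to compound 2 (within the scatter), is the only comparison that touches the same position, and it produced no change beyond the scatter.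

Compound 3 `CC(C)[C@H](NC(=O)CN(c1ncnc2c1ncn2C1CCCCO1)C1CC1)C(=O)OCc1ccccc1` differs from compound 2 by a group of 3 heavy atoms (3 carbon; no ring) in place of a group of 7 heavy atoms (4 carbon, 3 nitrogen; no ring), on a saturated chain carbon bound to an amide-type nitrogen and a carbonyl carbon. For the measured compounds named here, since the one change made at this position before left the read-out essentially unmoved, the step of a number 4.4 percentage points lower from compound 2 to compound 3 (within the scatter) is expected to stay within the scatter as well, with no direction favoured. On that basis compound 3 is estimated to give 48% in this assay, with a plausible range from 30% to 65%.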

Compound 3, a percentage reported as activity, at one dose (the size of the read-out at that dose, not a potency): 34.9%
Estimate against measurement, compound 3: 13.1 percentage points above; measured number inside the range.
By their numbers in this assay, from the lowest: compound 3; then compounds 1 and 2 (each within the scatter of the next).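

At this position, on a saturated chain carbon bound to an amide-type nitrogen and a carbonyl carbon, the side chain proves able to move the read-out in this assay, which the earlier step had not shown. Isopropyl in place of the group of 7 heavy atoms gives a number 17.5 percentage points lower from compound 2 to compound 3 (beyond the scatter), and isopropyl in place of hydroxymethyl gives a number 11.8 percentage points lower from compound 1 to compound 3 (beyond the scatter), so both steps run the same way and both lie beyond the scatter, though modestly. Nothing available explains why isopropyl stands lower than the other two side chains.

Going by these compounds, whether the lower number belongs to isopropyl alone or to carbon-only side chains in general stays open, and a longer chain or a benzyl group would bear on that. On these data alone, how a carboxylic acid or an amine on the side chain would compare with hydroxymethyl is also open.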